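This account rests on a few compounds, and the source may have more. Where it says the series, first, only, none or still open, it means among the compounds named here.

Three compounds share one core and differ only in the aryl group carried on an amide-type nitrogen of a urea. Compound 1 `COc1cc(NC(C)CCCNC(=O)Nc2ccc(C(F)(F)F)cc2)c2ncccc2c1` gives 22000 nM in a functional assay on SW-620 cells (Homo sapiens) for inhibition, read by MTT assay, with a stated time of 72 h; a lower number here means a stronger inhibitor, a higher number a weaker inhibitor. Compound 2 `COc1cc(NC(C)CCCNC(=O)Nc2cccc(F)c2)c2ncccc2c1` gives 27000 nM, and compound 3 `COc1cc(NC(C)CCCNC(=O)Nc2cccc(Cl)c2)c2ncccc2c1` gives 26000 nM. None of the three can be told apart on these numbers: the step of a 1.2-fold higher number from compound 1 to compound 2 (0.09 log units; within the scatter), the step of a 1.2-fold higher number from compound 1 to compound 3 (0.07 log units; within the scatter) and the step of a 1.0-fold lower number from compound 2 to compound 3 (0.02 log units; within the scatter) all sit inside the scatter of repeat measurements. Compound 3 therefore stands at a level indistinguishable from both of its neighbours.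

Compound 4 `COc1cc(NC(C)CCCNC(=O)Nc2ccc(Cl)cc2)c2ncccc2c1` has not yet been measured. It differs from compound 3 in one place: 4-chlorophenyl in place of 3-chlorophenyl on an amide-type nitrogen. The change keeps every atom and merely moves the chlorine to a different carbon of the same ring.

Going by the values given here, the steps that bear on this are the two that swapped the aryl group wholesale, from compound 1 to compound 2 and from compound 1 to compound 3, together with the halogen swap from compound 2 to compound 3. Each was inside the scatter, so the numbers give no sign that the aryl group matters here. Compound 4 is therefore expected to show no step beyond the scatter, no change at the digits printed from compound 3 to compound 4 (within the scatter), with an estimated value of 26000 nM, plausibly between 12000 nM and 55000 nM.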

Compound 4, half-maximal inhibitory concentration: 28000 nM
Compound 4: middle estimate off by 1.1-fold (0.03 log units), on the low side, and the stated range covers the measured number.
By their numbers in this assay, from the lowest: compounds 1, 3, 2 and 4 (each within the scatter of the next).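

In this assay, going by these compounds alone, moving the chlorine to a different carbon of the same ring, with every atom kept, gives no step that can be told from the scatter (a 1.1-fold higher number from compound 3 to compound 4 (0.03 log units; within the scatter)). The two wider swaps read the same way, 4-chlorophenyl in place of 3-fluorophenyl (a 1.0-fold higher number from compound 2 to compound 4 (0.02 log units; within the scatter)) and chloro in place of trifluoromethyl (a 1.3-fold higher number from compound 1 to compound 4 (0.10 log units; within the scatter)), so across these four compounds neither where the substituent sits on the ring nor which of these substituents it is separates one aryl group from another. No measurement shown explains why these aryl changes on the amide-type nitrogen make so little difference.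

Still open, as far as these compounds go, is whether a plain unsubstituted phenyl, or a phenyl carrying an amine or a carboxylic acid, would stay at this same level. Also open, from the compounds shown here alone, is what a longer chain between the urea and the shared core would do, since that chain is the same in all four compounds.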